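The source may report more compounds than this note shows. Statements on the series, on what has been measured and on what is new or still open speak of the compounds shown alone.

Measured so far:
Compound 1, `Cc1cc(=O)[nH]c2cc(NC(=O)c3cccc4ccccc34)ccc12`: 1.72
Compound 2, `Cc1cc(=O)[nH]c2cc(NC(=O)c3c(Br)cccc3Br)ccc12`: 1.75
Compound 3, `Cc1ccc(C(=O)Nc2ccc3c(C)cc(=O)[nH]c3c2)cc1`: 1.67

The three compounds share one core and differ only in the aryl group on the amide carbonyl. In a physicochemical assay for lipophilicity (on this read-out higher numbers stand for higher lipophilicity and lower numbers for lower lipophilicity), compound 3 gives the lowest of the three numbers, but the gaps are small: compound 1 lies higher by a margin within the scatter, and compound 2, the furthest, is also higher by a margin within the scatter. On these numbers the three cannot be ordered.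

Compound 4, `Cc1cc(=O)[nH]c2cc(NC(=O)c3cccc(Cl)c3)ccc12`, has not yet been measured in this assay. It differs from compound 3 in one place: 3-chlorophenyl in place of 4-methylphenyl on a carbonyl carbon

Going by the values given here, no step between measured compounds is known here, so the size of the change has to be judged from the spread of the three values. Because compound 1 gives 1.72 and compound 2 gives 1.75, both within the scatter of compound 3, the exchange of one aryl group for another of the same size appears to move this read-out little. The step from compound 3 to compound 4 is therefore expected to be small and slightly upward, a number 0.08 log units higher from compound 3 to compound 4 (within the scatter), not clearly beyond the scatter. For compound 4 an estimate of 1.75 is made, with a range from 1.5 to 2.05.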

Compound 4, partition coefficient: 1.69
Beside the measured number, compound 4's estimate is 0.06 log units above it; measured number inside the range.
By their numbers in this assay, from the lowest: compounds 3, 4, 1 and 2 (each within the scatter of the next).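

In this assay, going by these compounds alone, the exchange of 4-methylphenyl for 3-chlorophenyl on a carbonyl carbon whose other neighbour is an amide-type nitrogen gives the first step that can be read between two compounds differing in one place, a number 0.02 log units higher from compound 3 to compound 4 (within the scatter). The earlier compounds shown here could only be compared with one another across larger differences in the aryl group, whereas this pair keeps the heavy-atom count and the single six-membered aromatic ring of carbon only, and exchanges one ring substituent for another at a different ring position. At this place, then, this particular exchange gives no step beyond the scatter. The numbers come with nothing measured that would account for this result.

The substituent and its ring position differ together in this one pair. 3-methylphenyl or 4-chlorophenyl would be needed to tell the two apart. As far as these compounds go, it also remains open whether an aryl group carrying an amine or a carboxylic acid at this place would give a step beyond the scatter in this assay.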